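The compounds below may be only part of what the source reports. "The series", "measured", "known", "first", "only" and "open" are said of these compounds alone.

Compound 1 `COc1ccc(C(=O)Nc2ccc(C(=O)/C=C/c3nc(C)c(C)nc3C)cc2)cc1OC`: 5060 nM
Compound 2 `COc1cccc(OC)c1C(=O)Nc1ccc(C(=O)/C=C/c2nc(C)c(C)nc2C)cc1`: 8470 nM

Both compounds were tested in a functional assay on A549 cells (Homo sapiens) for antiproliferative activity, read by CCK-8 assay, with a stated time of 72 h; on this read-out higher numbers stand for weaker inhibition and lower numbers for stronger inhibition. Compound 1 gives 5060 nM, and compound 2 gives 8470 nM. Within the data shown here, compound 2 stands at the higher of the two numbers, but the single measured step, a 1.7-fold higher number from compound 1 to compound 2 (0.22 log units; within the scatter), lies within the scatter, so the two are not separated.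

Compound 3 `Cc1nc(C)c(/C=C/C(=O)c2ccc(NC(=O)c3ccc(F)cc3)cc2)nc1C` differs from compound 2 as follows: 4-fluorophenyl in place of 2,6-dimethoxyphenyl on a carbonyl carbon. Among the measured compounds shown here, the only measured step that bears on a change at this carbonyl carbon is the one from compound 1 to compound 2, which was small. For the measured compounds named here, no step with a fluorine-bearing group has been measured, so the expectation rests on that one step alone. For compound 3 the expected step is a 1.2-fold lower number from compound 2 to compound 3 (0.08 log units; within the scatter), with no change beyond the scatter anticipated. Compound 3 is therefore expected to give about 7000 nM in this assay, with a range from 2500 nM to 20000 nM.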

Compound 3, half-maximal inhibitory concentration: 4480 nM
For compound 3 the middle estimate is 1.6-fold (0.19 log units) above the measured one; the measured number falls inside the stated range.
By their numbers in this assay, from the lowest: compounds 3, 1 and 2 (each within the scatter of the next).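

In this assay, putting 4-fluorophenyl on the carbonyl carbon gives a 1.9-fold lower number from compound 2 to compound 3 (0.28 log units; within the scatter) and also a 1.1-fold lower number from compound 1 to compound 3 (0.05 log units; within the scatter); both steps lie within the scatter. This carbonyl carbon has therefore now carried a group with no methoxy substituent, and the numbers remain unseparated: 4-fluorophenyl, with 7 heavy atoms and 0 hydrogen-bond acceptors, stands with 2,6-dimethoxyphenyl, with 10 heavy atoms and 2 hydrogen-bond acceptors. Nothing available offers an explanation for this result.

On these data alone, all three groups at this place are substituted phenyl rings, so it remains open whether an amine, a carboxylic acid or a longer alkyl chain there would give a number beyond the scatter. As far as these compounds go, whether the same holds with an unsubstituted phenyl group also remains open.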